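The source may hold more compounds than are shown below. What is called first, only, known or untested is meant among the compounds shown, and "the series" means these compounds.

Measured compounds:
compound 1 `CC(C)(C)[C@@H](N)C(=O)N1CCN(CCCOc2ccc(C(=O)C3CC3)cc2)CC1`, an assay for binding affinity to histamine H2 receptor (Homo sapiens) (a higher number here means a weaker inhibitor, a lower number a stronger inhibitor), 19100 nM
compound 2 `C[C@@H](NC(=O)OC(C)(C)C)C(=O)N1CCN(CCCOc2ccc(C(=O)C3CC3)cc2)CC1`, 83200 nM
compound 3 `CC(C)(C)OC[C@@H](N)C(=O)N1CCN(CCCOc2ccc(C(=O)C3CC3)cc2)CC1`, 45700 nM

Compound 1 gives the lowest number of the three. Its distance to compound 3 is a 2.4-fold higher number from compound 1 to compound 3 (0.38 log units; beyond the scatter), and to compound 2 it is a 4.4-fold higher number from compound 1 to compound 2 (0.64 log units; beyond the scatter); between compound 2 and compound 3 the gap is a 1.8-fold lower number from compound 2 to compound 3 (0.26 log units; within the scatter).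

Compound 4 `N[C@H](CC1CCCCC1)C(=O)N1CCN(CCCOc2ccc(C(=O)C3CC3)cc2)CC1` has not yet been measured in this assay. Its difference from compound 1 is cyclohexylmethyl in place of tert-butyl on a saturated chain carbon bound to an amine nitrogen and a carbonyl carbon.

Of the measured steps, only the change from compound 1 to compound 3 touches the same place, where a tert-butyl was replaced by (tert-butoxy)methyl and the number rose by a 2.4-fold higher number from compound 1 to compound 3 (0.38 log units; beyond the scatter). Going by the values given here, no measured step swaps tert-butyl for cyclohexylmethyl, so the direction is uncertain. A modest step in either direction, or none beyond the scatter, is expected for compound 4, and the working estimate is a step of a 1.3-fold higher number from compound 1 to compound 4 (0.12 log units; within the scatter).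

Compound 4 is thus estimated at 25000 nM, with a range from 8000 nM to 80000 nM.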

Compound 4, inhibition constant: 20400 nM
Estimate against measurement, compound 4: 1.2-fold (0.09 log units) above; the measured number falls inside the stated range.
By their numbers in this assay, from the lowest: compounds 1 and 4 (each within the scatter of the next); then compounds 3 and 2 (each within the scatter of the next).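

In this assay, cyclohexylmethyl in place of tert-butyl on the saturated chain carbon bound to an amine nitrogen and a carbonyl carbon gives a 1.1-fold higher number from compound 1 to compound 4 (0.03 log units; within the scatter), so this position accepts a six-membered non-aromatic ring and three more carbons with no change beyond the scatter. Compound 4 also sets the two other compounds apart, with a 2.2-fold lower number from compound 3 to compound 4 (0.35 log units; beyond the scatter) and a 4.1-fold lower number from compound 2 to compound 4 (0.61 log units; beyond the scatter), which places both all-carbon groups carrying the free amine, in compound 1 and compound 4, at the low end of this small set. Nothing available explains these differences.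

On these data alone, whether a benzyl group or a longer straight alkyl chain at this position would also stay level with compound 1 remains open. Compound 2 differs at both the amine and the side group, so the share of each in its higher number also stays unresolved.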